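A few compounds are considered here, and "the series" means these few. Any claim that something is new, unique, unknown or untested is made for them only; others in the source may bear on it.

Values measured in a functional assay on A549 cells (Homo sapiens) for inhibition, read by CCK-8 assay, with a stated time of 48 h (on this read-out higher numbers stand for weaker inhibition and lower numbers for stronger inhibition), are as follows:
- compound 1 `COc1cc(-c2ccnc3cc(-c4cccc(C#N)c4)nn23)cc(OC)c1OC` gives > 10000 nM (a limit of the assay, not a number)
- compound 2 `COc1cc(-c2ccnc3cc(-c4ccc(C(F)(F)F)cc4)nn23)cc(OC)c1OC` gives 2070 nM (a measured number)

Among the compounds with values here, compound 2 at 2070 nM holds the only numeric value so far. The only other result is the limit reached by compound 1 (the limit of > 10000 nM in this assay, at which 1 of the 2 values shown sits).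

The next compound, compound 3 `COc1cc(-c2ccnc3cc(-c4ccc(N(C)C)cc4)nn23)cc(OC)c1OC`, carries dimethylamino in place of trifluoromethyl on an aromatic carbon. Within the data shown here, one measured step bears on this change. The step of an at least 4.8-fold lower number from compound 1 to compound 2 (0.68 log units; beyond the scatter) shows that exchanging the substituted phenyl group can move the value beyond the scatter. That step is only a bound, however, and it involves a different pair of groups, so it gives no firm size or direction here.

In this assay no step beyond the scatter is expected as the most likely outcome, though a wide margin on either side remains. The expected step is a 1.2-fold lower number from compound 2 to compound 3 (0.06 log units; within the scatter) in this estimate. The estimated value for compound 3 is 1800 nM, with an expected range from 350 nM to 9000 nM in this assay.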

Compound 3, half-maximal inhibitory concentration: 1100 nM
For compound 3 the middle estimate is 1.6-fold (0.21 log units) above the measured one, within the range that was stated.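

In this assay, replacing trifluoromethyl with dimethylamino on an aromatic carbon para to a large group gives a 1.9-fold lower number from compound 2 to compound 3 (0.27 log units; within the scatter), so these two groups are not told apart at this position, even though dimethylamino brings a hydrogen-bond acceptor that trifluoromethyl lacks. The change from 3-cyanophenyl to 4-(dimethylamino)phenyl gives an at least 9.0-fold lower number from compound 1 to compound 3 (0.95 log units; beyond the scatter), which adds a second step beyond the scatter out of compound 1, alongside the one to the 4-(trifluoromethyl)phenyl compound. Compound 1 stands at a limit of the assay, so both of these steps are bounds and not sizes: the limit of > 10000 nM in this assay, at which 1 of the 3 values shown sits.

Compound 1 differs from compound 3 in both the group and its place on the ring, so these compounds do not show which of the two accounts for the step. Within the data shown here, also open is whether the reading stays within the scatter for a primary amine, a morpholine or a carboxylic acid in the same place, since dimethylamino and trifluoromethyl are only two groups.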